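Benzyl ester removal in an oral tail flick series

A few compounds are considered here, and "the series" means these few. Any claim that something is new, unique, unknown or untested is made for them only; others in the source may bear on it.

Compound 1 `N=C(N)NCCC[C@H](NC(=O)CN(c1nc(Cl)nc2[nH]cnc12)C1CC1)C(=O)O` gives 51% in a functional assay on the whole organism (Tail, strain ICR) with Mus musculus as the target, in the tail flick test, with a stated time of 60 min, at a dose of 25 umol/kg by the oral route; on this read-out higher numbers stand for a stronger effect at the one dose given and lower numbers for a weaker effect. Compound 2 `N=C(N)NCCC[C@H](NC(=O)CN(c1nc(Cl)nc2[nH]cnc12)C1CC1)C(=O)OCc1ccccc1`, its benzyl ester, gives 30.6% in this assay, and compound 3 `CC(C)C[C@H](NC(=O)CN(c1nc(Cl)nc2[nH]cnc12)C1CC1)C(=O)OCc1ccccc1` gives 27.3% in this assay. The difference between compound 2 and compound 3 is in the core (a group of 3 heavy atoms (3 carbon; no ring) in place of a group of 6 heavy atoms (3 carbon, 3 nitrogen; no ring), on a saturated chain carbon, two bonds along the chain from an amide-type nitrogen and a carbonyl carbon), and the step of a number 3.3 percentage points lower from compound 2 to compound 3 (within the scatter). The change hydrogen in place of benzyl on an oxygen next to a carbonyl group gave the step of a number 20.4 percentage points higher from compound 2 to compound 1 (beyond the scatter). Compound 4 `CC(C)C[C@H](NC(=O)CN(c1nc(Cl)nc2[nH]cnc12)C1CC1)C(=O)O` carries the same change made on compound 3 (hydrogen in place of benzyl on an oxygen next to a carbonyl group), at the same place. Because the step of a number 20.4 percentage points higher from compound 2 to compound 1 (beyond the scatter) was seen on the core of compound 2, a step of similar size is expected here, a number 19.7 percentage points higher from compound 3 to compound 4 (beyond the scatter). Compound 4 is therefore estimated to reach 47% in this assay, between 33% and 62%.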

Compound 4, a percentage reported as activity, at one dose (the size of the read-out at that dose, not a potency): 36.4%
Compound 4: the middle estimate sits 10.6 percentage points above what was measured; the measured number falls inside the stated range.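

In this assay, hydrogen in place of benzyl on the second core gave a number 9.1 percentage points higher from compound 3 to compound 4 (within the scatter), and the smaller side chain in place of the larger one among the free acids gave a number 14.6 percentage points lower from compound 1 to compound 4 (beyond the scatter). Neither pair shows that a change carries over at a fixed size from one core to another; the two benzyl removals simply cannot be told apart: the same change on two cores in this assay, a number 20.4 percentage points higher (beyond the scatter) from compound 2 to compound 1 and a number 9.1 percentage points higher (within the scatter) from compound 3 to compound 4, 11.3 percentage points apart, within the scatter of two such steps. The two side-chain changes read the same way: the same change on two cores in this assay, a number 3.3 percentage points lower (within the scatter) from compound 2 to compound 3 and a number 14.6 percentage points lower (beyond the scatter) from compound 1 to compound 4, 11.3 percentage points apart, within the scatter of two such steps.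

The compounds shown leave open whether the benzyl step would hold on cores with other side chains, such as one ending in an amine or a carboxylic acid. They also leave open how a methyl or ethyl ester would compare with the benzyl ester.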